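The source may hold more compounds than are shown below. What is called first, only, known or untested is meant among the compounds shown, and "the series" means these compounds.

Measured compounds, growth inhibition in a functional assay on NCI-H460 cells (Homo sapiens) for inhibition, read by sulforhodamine B assay, with a stated time of 48 h; a higher number here means a weaker inhibitor of growth, a lower number a stronger inhibitor of growth:
- compound 1 `O=C(Nc1cccc(-n2cc(-c3ccncc3)c(-c3ccc(Cl)c(O)c3)n2)c1)Nc1cc(C(F)(F)F)cc(C(F)(F)F)c1` gives 413 nM
- compound 2 `COc1cc(-c2nn(-c3cccc(NC(=O)Nc4cccc(C(F)(F)F)c4)c3)cc2-c2ccncc2)ccc1Cl` gives 763 nM
- compound 3 `COc1cc(-c2nn(-c3cccc(NC(=O)c4ccccc4)c3)cc2-c2ccncc2)ccc1Cl` gives 394 nM

Compound 2 has the highest of the three numbers, but its gaps to compound 1 and to compound 3 are both within the scatter, so no ranking among the three can be read from these values. Among the measured compounds shown here, the only single-point step in the set, a 1.9-fold lower number from compound 2 to compound 3 (0.29 log units; within the scatter), alters the urea end of the molecule and also stays within the scatter.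

Compound 4 `COc1cc(-c2nn(-c3cccc(NC(=O)Nc4cc(C(F)(F)F)cc(C(F)(F)F)c4)c3)cc2-c2ccncc2)ccc1Cl` differs from compound 2 as follows: trifluoromethyl in place of hydrogen on an aromatic carbon. For the measured compounds named here, compound 1 carries the same bis(trifluoromethyl)phenyl urea on a core that differs from compound 2 elsewhere, so no single step connects it to compound 2; its value and that of compound 2 simply sit within the scatter of each other. Nothing in the set shows a change at the urea end moving the number beyond the scatter. Compound 4 is therefore expected to give 500 nM, range 200 nM to 1300 nM, in this assay. The implied step a 1.5-fold lower number from compound 2 to compound 4 (0.18 log units; within the scatter) is expected to lie within the scatter.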

Compound 4, concentration for 50% growth inhibition: 558 nM
Estimate against measurement, compound 4: 1.1-fold (0.05 log units) below, and the stated range covers the measured number.
By their numbers in this assay, from the lowest: compounds 3, 1, 4 and 2 (each within the scatter of the next).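

In this assay, adding a trifluoromethyl group on an aromatic carbon, meta to the existing trifluoromethyl group, gives a 1.4-fold lower number from compound 2 to compound 4 (0.14 log units; within the scatter) and is the first change shown at this position of the urea end. Compound 4 also makes compound 1 readable as a single-place neighbour: methyl on the oxygen gives a 1.4-fold higher number from compound 1 to compound 4 (0.13 log units; within the scatter), so this change on the aromatic oxygen also stays inside the scatter. No measured finding on these compounds accounts for either step.

Going by these compounds, whether an amine or a carboxylic acid at this aromatic carbon would move the number beyond the scatter remains open. Also open, on these data alone, is whether a longer chain on the oxygen, such as ethyl, would do so, or whether the step at the oxygen would hold with the urea end of compound 2.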